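The source may report more compounds than this note shows. Statements on the series, on what has been measured and on what is new or still open speak of the compounds shown alone.

In a functional assay, with a stated time of 20 min, tested at 0.5 mM (on this read-out higher numbers stand for a stronger effect at the one concentration tested and lower numbers for a weaker effect), compound 1, with the structure `Cn1c(=O)c(C(=O)Nc2ccccc2N)c(O)c2ccccc21`, gives 28.8%. Compound 2, with the structure `Nc1ccccc1NC(=O)c1c(O)c2ccccc2n(-c2ccccc2)c1=O`, differs from compound 1 by phenyl in place of methyl on an aromatic nitrogen; in this assay compound 2 gives 21.3%. The step of a number 7.5 percentage points lower from compound 1 to compound 2 (within the scatter) is the only measured example of this change among the compounds shown.

Compound 3 has the structure `Cn1c(=O)c(C(=O)NCCCCCCNC(=O)CCCCC2CCSS2)c(O)c2ccccc21`. It carries a different core from compound 1, and the difference between the two cores is not broken down here. In this assay compound 3 gives 28.4%, a number close to that of compound 1 and within the scatter of compound 2 as well.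

Compound 4, with the structure `O=C(CCCCC1CCSS1)NCCCCCCNC(=O)c1c(O)c2ccccc2n(-c2ccccc2)c1=O`, has not been measured. It differs from compound 3 by phenyl in place of methyl on an aromatic nitrogen, the same change as that from compound 1 to compound 2, and the two surroundings of the change are described in the same words. For the measured compounds named here, the step from compound 3 to compound 4 in this assay is therefore expected to resemble the one from compound 1 to compound 2: a small drift downward, if anything, that stays within the scatter, because the only measured instance is a number 7.5 percentage points lower from compound 1 to compound 2 (within the scatter). On this basis the step for compound 4 is estimated as a number 6.4 percentage points lower from compound 3 to compound 4 (within the scatter). Compound 4 is accordingly expected to give about 22% in this assay, with a likely range from 12% to 32%.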

Compound 4, a percentage reported as activity, at one concentration (the size of the read-out at that concentration, not a potency): 23.9%
Compound 4: middle estimate off by 1.9 percentage points, on the low side; the measured number falls inside the stated range.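

In this assay, phenyl in place of methyl on an aromatic nitrogen gives a number 4.5 percentage points lower from compound 3 to compound 4 (within the scatter), and set beside the earlier example on the other core, the two steps cannot be told apart: the same change on two cores in this assay, a number 7.5 percentage points lower (within the scatter) from compound 1 to compound 2 and a number 4.5 percentage points lower (within the scatter) from compound 3 to compound 4, 3 percentage points apart, within the scatter of two such steps. Within these four compounds, then, the change carries from the core of compound 1 to the core of compound 3 without any sign that the core alters the size of the step. This does not show that the change itself has a real effect on the read-out, as each step on its own lies within the scatter, and two pairs read at a single concentration say nothing about potency or about how the change would behave on any further core.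

The compounds shown leave open how this assay would respond to a group other than methyl or phenyl on the aromatic nitrogen, such as ethyl or benzyl. They also leave open whether the pair would keep the same close agreement with a longer chain in the amide part, or with an amine or a carboxylic acid added to the phenyl ring.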